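Changing one group: hydroxy to fluoro

A few compounds are considered here, and "the series" means these few. Any claim that something is new, unique, unknown or untested is made for them only; others in the source may bear on it.

Compound 1 `COc1cc(-n2cnc3ccc(-c4ccc([N+](=O)[O-])cc4)cc32)cc(OC)c1OC` gives 740 nM.
Compound 2 `COc1cc(-n2cnc3ccc(-c4ccc(O)cc4)cc32)cc(OC)c1OC` gives 4160 nM.

Both numbers come from a functional assay on MCF7 cells (Homo sapiens) for antiproliferative activity, read by MTT assay, with a stated time of 72 h; a lower number here means a stronger inhibitor, a higher number a weaker inhibitor. Within the data shown here, compound 2 has the higher of the two numbers, and the single neighbouring step, a 5.6-fold higher number from compound 1 to compound 2 (0.75 log units; beyond the scatter), is modest but beyond the scatter. Compound 3 `COc1cc(-n2cnc3ccc(-c4ccc(F)cc4)cc32)cc(OC)c1OC` differs from compound 2 by fluoro in place of hydroxy on an aromatic carbon. Among the measured compounds shown here, no measured step swaps hydroxy for fluoro, so the only guide is indirect. Because the hydroxy compound stands highest after the step of a 5.6-fold higher number from compound 1 to compound 2 (0.75 log units; beyond the scatter), a modest move back toward a lower number is expected, the estimated step being a 2.8-fold lower number from compound 2 to compound 3 (0.44 log units; beyond the scatter). Compound 3 is expected to give about 1500 nM, within 500 nM to 5000 nM.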

Compound 3, half-maximal inhibitory concentration: 1770 nM
For compound 3 the middle estimate is 1.2-fold (0.07 log units) below the measured one; the measured number falls inside the stated range.
By their numbers in this assay, from the lowest: compound 1; then compound 3; then compound 2.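

In this assay this position separates three groups: fluoro in place of hydroxy gives a 2.4-fold lower number from compound 2 to compound 3 (0.37 log units; beyond the scatter) and fluoro in place of nitro gives a 2.4-fold higher number from compound 1 to compound 3 (0.38 log units; beyond the scatter) on the same aromatic carbon. Fluoro therefore sits between nitro and hydroxy, and removing the hydrogen-bond donor of hydroxy does not raise the number here. Nothing shown explains this order. Three groups cannot show whether the order follows any simple trend. As far as these compounds go, how an amine or a carboxylic acid at this position would rank remains open.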